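This account rests on a few compounds, and the source may have more. Where it says the series, first, only, none or still open, it means among the compounds named here.

Working notes on the series in a functional assay on KB cells (Homo sapiens) for cytotoxicity; on this read-out higher numbers stand for weaker inhibition and lower numbers for stronger inhibition. Compound 1 (`N#Cc1cn(Cc2ccccc2)c2ncnc(N)c12`) reads > 100000 nM in this assay, and that value is a limit and not a number. Among the compounds with values here, compound 2 (`COCCOCn1cc(C(N)=S)c2c(N)ncnc21`) gives 183000 nM as the only true number so far, so it has no measured neighbour to be ranked against. Compound 3 (`NC(=S)c1cn(Cc2ccccc2)c2ncnc(N)c12`) is still to be measured. It differs from compound 2 by phenyl in place of 2-methoxyethoxy on a saturated chain carbon bound to an aromatic nitrogen with phenyl in place of 2-methoxyethoxy on a saturated chain carbon bound to an aromatic nitrogen. Within the data shown here, no measured step between compounds differing in one place exists, so the data set no size for this change. Starting from compound 2 at 183000 nM the readings remain very weak, and only a moderate move towards stronger inhibition is expected. The expected change is a 3.1-fold lower number from compound 2 to compound 3 (0.48 log units; beyond the scatter) and it may not clear the usual scatter by much. The estimate for compound 3 in this assay is 60000 nM within an expected range of 12000 nM to 200000 nM and a report as a limit remains possible.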

Compound 3, half-maximal inhibitory concentration: 32000 nM
The estimate for compound 3 lay 1.9-fold (0.27 log units) above the measured number, and the stated range covers the measured number.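

In this assay, the place on a saturated chain carbon bound to an aromatic nitrogen now has its first measured step, with phenyl in place of 2-methoxyethoxy: a 5.7-fold lower number from compound 2 to compound 3 (0.76 log units; beyond the scatter). This shows that the change at this place moves the reading beyond the scatter, although compound 3 at 32000 nM still sits in a very weak range. On the aromatic carbon, the group of 3 heavy atoms in place of the group of 2 heavy atoms gives an at least 3.1-fold lower number from compound 1 to compound 3 (0.49 log units; beyond the scatter), and that step has only one bound, as the reading for compound 1 is a limit and not a number: the limit of > 100000 nM in this assay, at which 1 of the 3 values shown sits.

The compounds shown leave open whether the lower number goes with the aromatic ring of phenyl or would also appear with cyclohexyl or a longer chain at the same place, and whether a substituted phenyl such as 4-chlorophenyl would move the reading further. They also leave open how an amide or a carboxylic acid on the aromatic carbon would compare with the group of 3 heavy atoms in compound 3.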